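Swapping a Furan for a Fluorinated Methoxyphenyl Ring

The source may report more compounds than this note shows. Statements on the series, on what has been measured and on what is new or still open speak of the compounds shown alone.

Compound 1 `FC(F)(F)c1ccc(-c2ccc3c(NCCCNCc4ccco4)ccnc3c2)cc1` gives 32000 nM
Compound 2 `Clc1ccc(Oc2ccc3c(NCCCNCc4ccco4)ccnc3c2)cc1` gives 14500 nM

Both compounds were measured in a physicochemical assay for solubility, with a stated time of 18 h, at pH 7.4; on this read-out higher numbers stand for higher solubility and lower numbers for lower solubility. Going by the values given here, compound 1 stands highest of the two numbers, the single measured step being a 2.2-fold lower number from compound 1 to compound 2 (0.34 log units; beyond the scatter), which alters a different part of the shared core. Compound 3 `COc1ccc(F)cc1CNCCCNc1ccnc2cc(-c3ccc(C(F)(F)F)cc3)ccc12` differs from compound 1 elsewhere: 5-fluoro-2-methoxyphenyl in place of furan-2-yl on a saturated chain carbon bound to an amine nitrogen. Among the compounds with values here, no measured step touches that place, so the expectation rests on the change alone; a step no larger than modest is expected, a 1.6-fold lower number from compound 1 to compound 3 (0.20 log units; within the scatter). Compound 3 is therefore estimated at 20000 nM, with a range from 8000 nM to 50000 nM.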

Compound 3, solubility: 32000 nM
Compound 3: middle estimate off by 1.6-fold (0.20 log units), on the low side, and the stated range covers the measured number.
By their numbers in this assay, from the lowest: compound 2; then compounds 1 and 3 (each within the scatter of the next).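

In this assay the swap of furan-2-yl for 5-fluoro-2-methoxyphenyl on a saturated chain carbon bound to an amine nitrogen gives no change at the digits printed from compound 1 to compound 3 (within the scatter) for this change. This place therefore takes a larger aromatic ring of carbon only without a shift beyond the scatter. Nothing measured here explains this result.

Still open, as far as these compounds go, is whether the same swap would hold with the 4-chlorophenoxy group of compound 2 in place of 4-(trifluoromethyl)phenyl. Also open, from the compounds shown here alone, is whether a carboxylic acid on this ring, or a longer chain, would move the number.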